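Swapping chloro for methyl in an inactive sulfonamide series

A few compounds are considered here, and "the series" means these few. Any claim that something is new, unique, unknown or untested is made for them only; others in the source may bear on it.

Compound 1 `O=S(=O)(Nc1ccc(-c2nc3ccccc3o2)cc1)c1cccc(Cl)c1` shares its sulfonamide core with compound 2 `O=S(=O)(Nc1ccc2oc(-c3ccccc3)nc2c1)c1ccccc1F` and compound 3 `COc1ccc(Cl)cc1S(=O)(=O)Nc1ccc2oc(-c3ccccc3)nc2c1`, which were all tested in an assay on isolated protein for inhibition of malate dehydrogenase, mitochondrial (Sus scrofa), with stated times of 45 min and 30 min; on this read-out lower numbers stand for stronger inhibition and higher numbers for weaker inhibition. In this assay compound 1 gives > 63000 nM, which is a limit of the assay rather than a number. Compound 2 likewise gives > 63000 nM, again a limit. Compound 3 gives > 63000 nM, also a limit. Going by the values given here, the one single-point change among the measured compounds, a step that the two limits leave unreadable from compound 2 to compound 3, therefore cannot be sized, and the only firm evidence is the limit of > 63000 nM in this assay, at which 3 of the 3 values shown sit.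

The new compound 4 `Cc1cccc(S(=O)(=O)Nc2ccc(-c3nc4ccccc4o3)cc2)c1` differs from compound 1 by methyl in place of chloro on an aromatic carbon. Among the compounds with values here, no measured step bears directly on this change, and the three values shown give no direction at all. With every neighbour sitting at the limit, the expectation for compound 4 is a step that the limit leaves unreadable from compound 1 to compound 4, that is, no change beyond the scatter. Compound 4 is thus estimated at 100000 nM, within a range from 40000 nM to 300000 nM, most likely reported again only as a limit.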

Compound 4, half-maximal inhibitory concentration: > 63000 nM
Compound 4: no number, only a limit; the forecaster's own chance of this, stated with the estimate: 85%; the middle value lies beyond the limit too.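

The step from compound 1 to compound 4 cannot be read: in this assay each of these two compounds gives only a limit, not a number. Whether 3-chlorophenyl and 3-methylphenyl differ at all, and what would give a measurable value on the shared core, stays open: the limit of > 63000 nM in this assay, at which 4 of the 4 values shown sit.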